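Swapping Fluoro for Methyl: What to Expect for Compound 4

The source may hold more compounds than are shown below. What is called first, only, known or untested is meant among the compounds shown, and "the series" means these compounds.

Measured so far:
compound 1 `Cc1nc(S(C)(=O)=O)ccc1Oc1ncnc(OC2CCN(C(=O)OC(C)C)CC2)c1F` gives 21 nM in a functional assay on isolated protein for inhibition of Glucose-dependent insulinotropic receptor (Homo sapiens), read by HTRF and cAMP accumulation; a higher number here means that more compound is needed for the effect, a lower number that less compound is needed
compound 2 `Cc1nc(S(C)(=O)=O)ccc1Oc1ncnc(OC2CCN(C(=O)OC(C)F)CC2)c1F` gives 65.5 nM in this assay
compound 3 `Cc1nc(S(C)(=O)=O)ccc1Oc1ncnc(OC2CCN(C(=O)C(C)(F)F)CC2)c1F` gives 37 nM in this assay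

Compound 2 and compound 1 differ by methyl in place of fluoro on a saturated chain carbon bound to an oxygen next to a carbonyl group and a saturated chain carbon, a change that gave a 3.1-fold lower number from compound 2 to compound 1 (0.49 log units; beyond the scatter). Compound 3 differs from compound 2 by a group of 4 heavy atoms (2 carbon, 2 fluorine; no ring) in place of a group of 4 heavy atoms (2 carbon, 1 oxygen, 1 fluorine; no ring), on a carbonyl carbon, a step of a 1.8-fold lower number from compound 2 to compound 3 (0.25 log units; within the scatter). Compound 4 `Cc1nc(S(C)(=O)=O)ccc1Oc1ncnc(OC2CCN(C(=O)C(C)(C)F)CC2)c1F` has not been measured; it differs from compound 3 by methyl in place of fluoro on a saturated chain carbon bound to a carbonyl carbon, a fluorine atom and a saturated chain carbon. For the measured compounds named here, this is the same kind of change as the one from compound 2 to compound 1, but not the same: in compound 2 the carbon that loses the fluoro is bound to an oxygen next to a carbonyl group and a saturated chain carbon, whereas in compound 3 it is bound to a carbonyl carbon, a fluorine atom and a saturated chain carbon. For compound 4 a step of about a 1.9-fold lower number from compound 3 to compound 4 (0.27 log units; within the scatter) in this assay is expected, a little smaller than the earlier one, resting on the step of a 3.1-fold lower number from compound 2 to compound 1 (0.49 log units; beyond the scatter). Compound 4 is therefore estimated at 20 nM, most likely between 8 nM and 50 nM.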

Compound 4, half-maximal effective concentration: 76.3 nM
For compound 4 the middle estimate is 3.8-fold (0.58 log units) below the measured one; measured number above the stated range.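

Methyl in place of fluoro does not carry a fixed effect from one core to another in this series, since in this assay the step reverses direction: the same change on two cores in this assay, a 3.1-fold lower number (0.49 log units; beyond the scatter) from compound 2 to compound 1 and a 2.1-fold higher number (0.31 log units; beyond the scatter) from compound 3 to compound 4, 6.4-fold (0.81 log units) apart, beyond the scatter of two such steps

Set against the other two compounds, the outcome is a 3.6-fold higher number from compound 1 to compound 4 (0.56 log units; beyond the scatter) and a 1.2-fold higher number from compound 2 to compound 4 (0.07 log units; within the scatter), so the new step, a 2.1-fold higher number from compound 3 to compound 4 (0.31 log units; beyond the scatter), is not an isolated reading of compound 4 alone. For the compounds shown here, with one pair on each core, this shows only that the step can change direction, not why it does so or which direction it would take on a further core.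

Going by these compounds, what an amine or a longer chain on the carbonyl carbon would give remains open. So does how the methyl-for-fluoro step behaves on any other core.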